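The source may hold more compounds than are shown below. What is called first, only, known or untested is meant among the compounds shown, and "the series" means these compounds.

Compound 1 `CCCNCc1nccn1Nc1nc(C)nc2c1c(C)nn2-c1ccc(OC)cc1C` is the weakest of the three measured compounds in a functional assay on CHO cells for antagonist activity at corticotropin-releasing factor receptor 1 (Homo sapiens), read by cAMP accumulation (a higher number here means a weaker inhibitor, a lower number a stronger inhibitor), giving 400 nM. Compound 2 `CC[C@H](COC)Nc1nc(C)nc2c1c(C)nn2-c1ccc(OC)cc1C` gives 210 nM, and compound 3 `CCC[C@H](CO)Nc1nc(C)nc2c1c(C)nn2-c1ccc(OC)cc1C` gives 76 nM. The step of a 1.9-fold lower number from compound 1 to compound 2 (0.28 log units; within the scatter) stays within the scatter, whereas a 5.3-fold lower number from compound 1 to compound 3 (0.72 log units; beyond the scatter) and a 2.8-fold lower number from compound 2 to compound 3 (0.44 log units; beyond the scatter) both go beyond it.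

Compound 4 `CCC(CC)Nc1nc(C)nc2c1c(C)nn2-c1ccc(OC)cc1C` differs from compound 1 in one place: pentan-3-yl in place of 2-((propylamino)methyl)-1H-imidazol-1-yl on a nitrogen on an aromatic ring. Both measured steps away from compound 1 replace the same imidazolyl group with a small branched alkyl bearing a single oxygen, and both lower the number, modestly in the case of compound 3. Pentan-3-yl carries no oxygen at all, so neither measured step matches it exactly, but both point in the same direction.

He therefore expects compound 4 to land below compound 1 in this assay, with a step of roughly a 3.6-fold lower number from compound 1 to compound 4 (0.56 log units; beyond the scatter), and estimates for compound 4 a value of about 110 nM, within a range from 35 nM to 350 nM.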

Compound 4, inhibition constant: 42 nM
Estimate against measurement, compound 4: 2.6-fold (0.42 log units) above; the measured number falls inside the stated range.
By their numbers in this assay, from the lowest: compounds 4 and 3 (each within the scatter of the next); then compounds 2 and 1 (each within the scatter of the next).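

Pentan-3-yl carries no oxygen, with 0 hydrogen-bond donors and 0 hydrogen-bond acceptors, yet on the nitrogen on an aromatic ring it gives the largest step yet seen from the imidazolyl compound in this assay: a 9.5-fold lower number from compound 1 to compound 4 (0.98 log units; beyond the scatter). An oxygen in the group at this place is therefore not needed for a low number, which compounds 2 and 3 could not show. Against the two oxygen-bearing groups the result splits: a 1.8-fold lower number from compound 3 to compound 4 (0.26 log units; within the scatter) leaves pentan-3-yl and 1-(hydroxymethyl)butyl indistinguishable, whereas a 5.0-fold lower number from compound 2 to compound 4 (0.70 log units; beyond the scatter) sets pentan-3-yl clearly apart from 1-(methoxymethyl)propyl.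

Nothing given here accounts for these differences. Still open, on these data alone, is how the number would respond to a longer chain such as heptan-4-yl, or to an amine or a carboxylic acid on the pentan-3-yl chain.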